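This account rests on a few compounds, and the source may have more. Where it says the series, first, only, none or still open, it means among the compounds named here.

Compound 2 `Brc1ccc(Oc2cc(Br)cc(Br)c2OCc2ccccc2)c(Br)c1` — in a functional assay on U-937 cells (Homo sapiens) for cytotoxicity, read by MTT assay, with a stated time of 24 h (on this read-out higher numbers stand for weaker inhibition and lower numbers for stronger inhibition), compound 2 gives 29 ug/mL
Compound 1 `COc1ccccc1N1CCN(CCCCCOc2c(Br)cc(Br)cc2Oc2ccc(Br)cc2Br)CC1` — in this assay compound 1 gives 37.5 ug/mL

For the measured compounds named here, on the two numbers so far, compound 2 has the lowest reading in this assay, with compound 1 as its only neighbour; the gap between them lies within the scatter of repeated measurements, so nothing can be said about which of the two inhibits more strongly. Compound 3 `BrCCCCCOc1c(Br)cc(Br)cc1Oc1ccc(Br)cc1Br` has not yet been measured. It differs from compound 2 in one place: 4-bromobutyl in place of phenyl on a saturated chain carbon bound to an oxygen on an aromatic ring. Going by the values given here, no step between measured compounds is known for a change of this kind, so there is no basis for expecting a shift beyond the scatter in this assay in either direction. The expected step from compound 2 to compound 3 is therefore small, a 1.0-fold higher number from compound 2 to compound 3 (0.01 log units; within the scatter). For compound 3 the estimate in this assay is 30 ug/mL, with a range from 15 ug/mL to 60 ug/mL.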

Compound 3, half-maximal inhibitory concentration: 29.5 ug/mL
The estimate for compound 3 lay 1.0-fold (0.01 log units) above the measured number; low and high end bracket the measured number.
By their numbers in this assay, from the lowest: compounds 2, 3 and 1 (each within the scatter of the next).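

For the compounds shown here, replacing phenyl with 4-bromobutyl on a saturated chain carbon bound to an oxygen on an aromatic ring provides the only measured step at this position so far: in this assay the replacement gives a 1.0-fold higher number from compound 2 to compound 3 (0.01 log units; within the scatter) and leaves the two readings impossible to tell apart. A six-membered aromatic ring of carbon leaves and a group with no ring enters, so in this pair the phenyl ring is not needed for a reading of this size. Nothing measured here explains why the two groups give such similar readings.

Going by these compounds, whether an amine, a carboxylic acid or a longer chain at this position would move the reading beyond the scatter remains open. A single pair also cannot show how far this result extends to other groups.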